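The source may hold more compounds than are shown below. What is called first, only, known or untested is meant among the compounds shown, and "the series" means these compounds.

Measured compounds:
- compound 1 `COc1ccc(/C=C\c2cc(OC)c(OC)c(OC)c2)cc1OCc1ccc(CN2CCCCC2C(=O)O)cc1`: > 10000 nM
- compound 2 `COc1ccc(/C=C\c2cc(OC)c(OC)c(OC)c2)cc1OCc1ccc(CN2CC[C@@H](O)C2)cc1`: > 10000 nM
- compound 3 `COc1ccc(/C=C\c2cc(OC)c(OC)c(OC)c2)cc1OCc1ccc(CN2CC[C@H](O)C2)cc1`: > 10000 nM

In a functional assay on B16-F10 cells (Mus musculus) for antiproliferative activity, read by CCK-8 assay, with a stated time of 48 h (on this read-out higher numbers stand for weaker inhibition and lower numbers for stronger inhibition), compound 3 gives > 10000 nM, which is a limit of the assay rather than a number. Compound 1 likewise gives only the limit > 10000 nM. Compound 2 also stops at the limit > 10000 nM. Because of the limit of > 10000 nM in this assay, at which 3 of the 3 values shown sit, none of the steps among these three can be read: a step that the two limits leave unreadable from compound 1 to compound 2, a step that the two limits leave unreadable from compound 1 to compound 3 and a step that the two limits leave unreadable from compound 2 to compound 3 all stay without a size, and the fact that compounds 2 and 3 differ only in the configuration as drawn adds nothing measurable either.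

Compound 4 `COc1ccc(/C=C\c2cc(OC)c(OC)c(OC)c2)cc1OCc1ccc(CO)cc1` differs from compound 3 in one place: hydroxy in place of 3-hydroxypyrrolidin-1-yl on a saturated chain carbon bound to an aromatic carbon. No measured step bears on this change, so no direction beyond the scatter can be argued from the data shown; the only anchor is that compound 3 sits at the limit in this assay. The expected step of an at least 1.2-fold lower number from compound 3 to compound 4 (0.09 log units; that floor lies within the scatter) is therefore set as roughly nothing, with wide uncertainty. Compound 4 is estimated at 8000 nM, within a range from 800 nM to 40000 nM.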

Compound 4, half-maximal inhibitory concentration: 6600 nM
Compound 4: middle estimate off by 1.2-fold (0.08 log units), on the high side; low and high end bracket the measured number.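

In this assay, within the data shown here, compound 4 gives 6600 nM, the first value that is a number and not a limit, so this place on the saturated chain carbon bound to an aromatic carbon can carry a group that yields a readable result. Hydroxy in place of 3-hydroxypyrrolidin-1-yl gives an at least 1.5-fold lower number from compound 3 to compound 4 (0.18 log units; that floor lies within the scatter) and an at least 1.5-fold lower number from compound 2 to compound 4 (0.18 log units; that floor lies within the scatter), while hydroxy in place of 2-carboxypiperidin-1-yl gives an at least 1.5-fold lower number from compound 1 to compound 4 (0.18 log units; that floor lies within the scatter). These steps are only floors, and their true size stays unknown because the other compounds give no number: the limit of > 10000 nM in this assay, at which 3 of the 4 values shown sit.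

As far as these compounds go, whether a methoxy, a primary amine or a carboxylic acid at this place would also give a number in this assay remains open. The compounds shown also do not separate the loss of the ring from the arrival of hydroxy.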